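This account rests on a few compounds, and the source may have more. Where it says the series, first, only, none or still open, it means among the compounds named here.

Measured so far in a physicochemical assay for lipophilicity, read by HPLC; a lower number here means a more polar compound, a higher number a more lipophilic compound:
Compound 1 `Oc1ccc(/C=C/c2ccc(/C=C/c3ccc(O)cc3)c(C(F)(F)F)c2)cc1`: compound 1 gives 5.64.
Compound 2 `Oc1ccc(/C=C/c2ccc(/C=C/c3ccc(O)cc3)c(OCCCC(F)(F)F)c2)cc1`: compound 2 gives 5.79.
Compound 3 `COc1ccc(/C=C/c2ccc(/C=C/c3ccc(OC)c(C(F)(F)F)c3)cc2O)cc1`: compound 3 gives 7.17.

Compound 3 stands highest of the three numbers in this assay. The nearest is compound 2, whose number lies beyond the scatter below it, and the furthest is compound 1, further below still. Among the measured compounds shown here, compound 3 differs from compound 1 and from compound 2 in more than one place, so no single step joins them; their values show only that the gaps are beyond the scatter. For the measured compounds named here, the one step drawn within the set, a number 0.15 log units higher from compound 1 to compound 2 (within the scatter), concerns a different change on the shared core and lies within the scatter, so it has no direct bearing on the step at hand.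

Compound 4 `COc1ccc(/C=C/c2ccc(/C=C/c3ccc(OC)c(C(F)(F)F)c3)cc2OC)cc1` differs from compound 3 by methyl in place of hydrogen on an oxygen on an aromatic ring. Going by the values given here, no measured pair in the set carries this change, so the expectation rests on the value of compound 3, 7.17, and on what enters. A modest rise in this assay is expected, a number 0.43 log units higher from compound 3 to compound 4 (beyond the scatter), probably at the edge of the scatter or just beyond it. Compound 4 is therefore estimated at 7.6, with a range from 7.2 to 8.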

Compound 4, partition coefficient: > 7
Compound 4: no number, only a limit (the forecaster's own chance of this, stated with the estimate: 10%); the middle value lies beyond the limit too.
By their numbers in this assay, from the lowest: compounds 1 and 2 (each within the scatter of the next); then compound 3.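

In this assay compound 4 gives > 7, a limit and not a number. The step from compound 3 to compound 4 therefore cannot be read: the limit of > 7 in this assay, at which 1 of the 4 values shown sits.

The compounds shown leave open the size and direction of any change in this assay with methyl in place of hydrogen on an oxygen on an aromatic ring.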